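Compound 3: a chlorophenyl isomer awaiting its measurement

The source may hold more compounds than are shown below. What is called first, only, known or untested is meant among the compounds shown, and "the series" means these compounds.

Values so far in a functional assay on MCF7 cells (Homo sapiens) for inhibition, read by MTT assay (on this read-out higher numbers stand for weaker inhibition and lower numbers for stronger inhibition), are these
Compound 1 `COc1cc2ncnc(Nc3ccc(NC(=O)c4ccccc4Cl)cc3)c2cc1OC` gives 36000 nM
Compound 2 `COc1cc2ncnc(Nc3ccc(NC(=O)c4cccc(Cl)c4)cc3)c2cc1OC` gives 18000 nM

Compound 2 at 18000 nM stands level with compound 1 at 36000 nM within the scatter. Compound 3 `COc1cc2ncnc(Nc3ccc(NC(=O)c4ccc(Cl)cc4)cc3)c2cc1OC` differs from compound 2 as follows: 4-chlorophenyl in place of 3-chlorophenyl on a carbonyl carbon with 4-chlorophenyl in place of 3-chlorophenyl on a carbonyl carbon. Among the measured compounds shown here, only one measured step bears on this change. Because a 2.0-fold lower number from compound 1 to compound 2 (0.30 log units; within the scatter) stayed within the scatter, no step beyond the scatter is expected in this assay here. The expected step is a 1.1-fold higher number from compound 2 to compound 3 (0.05 log units; within the scatter) and no more. Compound 3 is estimated at 20000 nM with an expected range of 8000 nM to 45000 nM in this read-out.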

Compound 3, half-maximal inhibitory concentration: 30000 nM
The estimate for compound 3 lay 1.5-fold (0.18 log units) below the measured number; measured number inside the range.
By their numbers in this assay, from the lowest: compounds 2, 3 and 1 (each within the scatter of the next).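

In this assay, the 4-chlorophenyl group on the carbonyl carbon gives a 1.7-fold higher number from compound 2 to compound 3 (0.22 log units; within the scatter) and a 1.2-fold lower number from compound 1 to compound 3 (0.08 log units; within the scatter). With all three chlorophenyl isomers now in hand, no change in where the chlorine sits on this ring gives a step beyond the scatter. Nothing available explains these small differences. The compounds shown leave open whether a different group on this ring, such as a methoxy group or an amine in place of the chlorine, would move the number beyond the scatter. They also leave open whether replacing the whole chlorophenyl group on the carbonyl carbon would do so.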